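The source may hold more compounds than are shown below. What is called first, only, known or untested is meant among the compounds shown, and "the series" means these compounds.

Measured compounds:
Compound 1 `O=C1N(Cc2ccc(Cl)cc2Cl)c2cccn2S(=O)(=O)N1Cc1ccccc1`: in an ADME assay on MT4 cells (Homo sapiens) for cytotoxicity, read by MTT assay, with a stated time of 5 days (a higher number here means that more compound is tolerated, a lower number that less compound is tolerated), compound 1 gives 218000 nM.
Compound 2 `N#Cc1ccccc1CN1C(=O)N(Cc2cccc(Cl)c2)S(=O)(=O)n2cccc21`: in this assay compound 2 gives > 293000 nM, which is a limit of the assay and not a number.
Compound 3 `O=C1N(Cc2ccc(Cl)cc2Cl)c2cccn2S(=O)(=O)N1Cc1cccc(Br)c1`: in this assay compound 3 gives > 243000 nM, again a limit of the assay rather than a number.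

Compound 3 thus stands at a limit, (the limit of > 243000 nM in this assay, at which 1 of the 3 values shown sits), and compound 2 sits at another, (the limit of > 293000 nM in this assay, at which 1 of the 3 values shown sits), so only compound 1 gives a plain number. Going by the values given here, the one measured step that ends at compound 3, an at least 1.1-fold higher number from compound 1 to compound 3 (0.04 log units; that floor lies within the scatter), is itself cut off by a limit and reaches no further than the scatter. Compound 4 `O=C1N(Cc2ccc(Cl)cc2Cl)c2cccn2S(=O)(=O)N1Cc1cccc(Cl)c1` differs from compound 3 by chloro in place of bromo on an aromatic carbon. Among the compounds with values here, no measured step exchanges one of these two halogens for the other, so the expectation rests only on where compound 3 stands. A change of this kind is expected to shift the number by little, if anything, beyond the scatter. Compound 4 is therefore expected to lie around 250000 nM, between 120000 nM and 450000 nM. The expected step is a step that the limit leaves unreadable from compound 3 to compound 4, with a good chance that this assay again reports only a limit.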

Compound 4, half-maximal cytotoxic concentration: > 251000 nM
Compound 4: no number, only a limit; the forecaster's own chance of this, stated with the estimate: 65%; middle value at least 1.0-fold (0.00 log units) away from the limit.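

Chloro on this ring, like bromo, leaves the read-out in this assay at a limit and not a number: the limit of > 251000 nM in this assay, at which 1 of the 4 values shown sits. The steps from compound 3 and from compound 2 to compound 4 cannot be read, as both ends of each are limits. Going by these compounds alone, the one readable step, chloro in place of hydrogen, is an at least 1.1-fold higher number from compound 1 to compound 4 (0.06 log units; that floor lies within the scatter), so chloro, like bromo before it, shows no drop in the amount of compound tolerated, and any rise stays unproven.

As far as these compounds go, how far compound 3 and compound 4 really lie past their limits, and whether they differ at all, stays open. So does whether a different group at this place, such as an amine, a carboxylic acid or a longer chain, would bring the cells' tolerance down to a plain number.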